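This account rests on a few compounds, and the source may have more. Where it says the series, first, only, none or still open, it means among the compounds named here.

Measured in a functional assay on SW-620 cells (Homo sapiens) for cytotoxicity, read by MTT assay, with a stated time of 48 h; a lower number here means a stronger inhibitor, a higher number a weaker inhibitor:

compound 1 `CCCCCCCCNC(=O)[C@@H](NC(=O)c1cccs1)[C@@H](C)O` gives 136000 nM
compound 2 `C/C=C/C=C/C(=O)N[C@H](C(=O)NCCCCCCCC)[C@@H](C)O` gives 200000 nM
compound 3 `CCCCCCCCCCCCCCCCCCNC(=O)[C@@H](NC(=O)c1cccs1)[C@@H](C)O` gives 200000 nM

Compound 3 stands level with compound 2 at the digits given, the two together the highest of the three numbers; its furthest neighbour is compound 1, and the step of a 1.5-fold higher number from compound 1 to compound 3 (0.17 log units; within the scatter) is within the scatter. Compound 4 `C/C=C/C=C/C(=O)N[C@H](C(=O)NCCCCCCCCCCCCCCCCCC)[C@@H](C)O` has not yet been measured. The change from compound 3 to compound 4 is penta-1,3-dien-1-yl in place of thiophen-2-yl on a carbonyl carbon. For the measured compounds named here, one measured step bears on it directly: the same exchange on the shorter chain, a 1.5-fold higher number from compound 1 to compound 2 (0.17 log units; within the scatter), which stayed within the scatter. The chain-lengthening step a 1.5-fold higher number from compound 1 to compound 3 (0.17 log units; within the scatter) gives no sign that the longer chain behaves differently on this point. On that basis no movement beyond the scatter is expected in this assay for compound 4, with at most a slight drift towards a higher number. The expected step is a 1.3-fold higher number from compound 3 to compound 4 (0.10 log units; within the scatter). Compound 4 is therefore estimated at 250000 nM, with a range of 120000 nM to 500000 nM; the weak end of the measured numbers leaves some chance that only a limit is reported.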

Compound 4, half-maximal inhibitory concentration: 200000 nM
The estimate for compound 4 lay 1.3-fold (0.10 log units) above the measured number, within the range that was stated.
By their numbers in this assay, from the lowest: compounds 1, 2, 3 and 4 (each within the scatter of the next).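

In this assay, penta-1,3-dien-1-yl in place of thiophen-2-yl on a carbonyl carbon now also reads on the long chain, giving no change at the digits printed from compound 3 to compound 4 (within the scatter), so the exchange reads alike on both cores: the same change on two cores in this assay, a 1.5-fold higher number (0.17 log units; within the scatter) from compound 1 to compound 2 and no change at the digits printed (within the scatter) from compound 3 to compound 4, 1.5-fold (0.17 log units) apart, within the scatter of two such steps
Adding decyl to the chain now reads with penta-1,3-dien-1-yl as well as with thiophen-2-yl, giving no change at the digits printed from compound 2 to compound 4 (within the scatter), and the two chain steps agree: the same change on two cores in this assay, a 1.5-fold higher number (0.17 log units; within the scatter) from compound 1 to compound 3 and no change at the digits printed (within the scatter) from compound 2 to compound 4, 1.5-fold (0.17 log units) apart, within the scatter of two such steps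
With both changes read in both settings, compounds 1, 2, 3 and 4 show no step beyond the scatter at either place.

From the compounds shown here alone, whether an amine or a carboxylic acid in place of penta-1,3-dien-1-yl on that carbonyl carbon would move the number beyond the scatter stays open. The same holds for a chain longer than that of compound 4.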